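The compounds below may be only part of what the source reports. "The series", "measured", "known", "first", "only" and "open" are said of these compounds alone.

Measured in a functional assay on LNCaP cells (Homo sapiens) for antiproliferative activity, read by MTT assay, with a stated time of 96 h; a higher number here means a weaker inhibitor, a lower number a stronger inhibitor:
- compound 1, `CC(C)N1CCN(c2ccc3nnnc(Nc4cccc(OC(F)(F)F)c4)c3n2)CC1`: 10700 nM
- compound 2, `CC(C)(C)OC(=O)N1CCC(CNc2ccc3nnnc(Nc4cccc(OC(F)(F)F)c4)c3n2)CC1`: > 100000 nM

Among the compounds with values here, compound 1 holds the only definite number in this set: in this assay compound 1 gives 10700 nM. For compound 2 the result of > 100000 nM is a limit of the assay and not a number, and it sits at the limit of > 100000 nM in this assay, at which 1 of the 2 values shown sits. Within the data shown here, no pair of these two differs in just one place, so no measured step is available.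

Compound 3, `OCCNc1ccc2nnnc(Nc3cccc(OC(F)(F)F)c3)c2n1`, is not yet measured. It differs from compound 1 by (2-hydroxyethyl)amino in place of 4-isopropylpiperazin-1-yl on an aromatic carbon. Among the measured compounds shown here, with no measured step to lean on, the size of this change can only be judged from the two compounds themselves. For compound 2, which also carries an amino-linked group at the same place, the result of > 100000 nM is a limit of the assay. Compound 1 gives 10700 nM. Compound 3 is therefore expected to land somewhat weaker than compound 1, with a step of a 2.3-fold higher number from compound 1 to compound 3 (0.37 log units; beyond the scatter) that may well stay within the scatter. The estimate for compound 3 is 25000 nM, from 8000 nM to 100000 nM.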

Compound 3, half-maximal inhibitory concentration: 42900 nM
For compound 3 the middle estimate is 1.7-fold (0.23 log units) below the measured one, within the range that was stated.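

Within the data shown here, replacing 4-isopropylpiperazin-1-yl with (2-hydroxyethyl)amino on this aromatic carbon, next to the ring nitrogen, gives a 4.0-fold higher number from compound 1 to compound 3 (0.60 log units; beyond the scatter) in this assay, the only measured step at this position. The step is beyond the scatter, so the group at this place does affect the reading, although the size of the step is modest. A definite reading also remains after the change, which shows that the non-aromatic ring of compound 1 is not needed for compound 3 to give a number in this assay.

On these data alone, this single change removes the ring and the isopropyl group and adds a hydroxyl group all at once, so the data cannot separate their contributions, and how an unsubstituted piperazine, a morpholine or a longer hydroxyalkyl chain would read at this place stays open. Compound 2 adds no second step to set beside this one, as its result is a limit of the assay and not a number: the limit of > 100000 nM in this assay, at which 1 of the 3 values shown sits.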